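Notes on a fluorobenzyl amide series: compound 2 to compound 4

The compounds below may be only part of what the source reports. "The series", "measured", "known", "first", "only" and "open" are said of these compounds alone.

Measured compounds:
compound 1 `C[C@@H](CO)Nc1nc(C(=O)NCc2ccc(F)cc2)c(O)c2ncccc12`: "not determined" (no result reported)
compound 2 `CS(=O)(=O)Oc1c(C(=O)NCc2ccc(F)cc2)nc(Br)c2cccnc12`: > 20000 nM
compound 3 `CS(=O)(=O)NCCCN(c1nc(C(=O)NCc2ccc(F)cc2)c(O)c2ncccc12)S(C)(=O)=O`: 7000 nM

In a functional assay on HCT-116 cells (Homo sapiens) for cytotoxicity, read by MTT assay, with a stated time of 72 h (a lower number here means a stronger inhibitor, a higher number a weaker inhibitor), compound 1 gives "not determined" (no result reported), so it adds nothing to the numbers. Compound 3 gives 7000 nM in this assay. For compound 2 this assay reports only a limit, > 20000 nM, as noted in the limit of > 20000 nM in this assay, at which 1 of the 3 values shown sits, so compound 2 stands without a single number at the weak end of what is shown. Compound 4 `COC(=O)CNc1c(C(=O)NCc2ccc(F)cc2)nc(Br)c2cccnc12` differs from compound 2 by ((methoxycarbonyl)methyl)amino in place of (methylsulfonyl)oxy on an aromatic carbon. Within the data shown here, no step between measured compounds is available to set the size of such a change. Compound 3, with 7000 nM, shows that a single number can be reached in this series, and a step beyond the scatter toward stronger inhibition is expected, an at least 1.6-fold lower number from compound 2 to compound 4 (0.22 log units; that floor lies within the scatter). Compound 4 is estimated at 12000 nM, with a range from 4000 nM to 40000 nM, and a real chance that only a limit is again reported.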

Compound 4, half-maximal inhibitory concentration: > 10000 nM
Compound 4: no number, only a limit; the forecaster's own chance of this, stated with the estimate: 45%; the middle value lies beyond the limit too.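

Compound 2 and compound 4 are both reported only as limits in this assay, and no step can be read between them. The compounds shown leave open what size of change ((methoxycarbonyl)methyl)amino brings in place of (methylsulfonyl)oxy in this assay.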